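Trimming an Allylamino Group Back to Methylamino

The compounds below may be only part of what the source reports. "The series", "measured", "known", "first", "only" and "open" are said of these compounds alone.

The measured compounds, all tested in a functional assay on PANC-1 cells (Homo sapiens) for cytotoxicity, read by resazurin assay, with a stated time of 48 h; on this read-out higher numbers stand for weaker inhibition and lower numbers for stronger inhibition:
- compound 1, `CCOc1ccc(-n2nnc3n[nH]c(Nc4ccccc4)c3c2=O)cc1`, gives 13100 nM
- compound 2, `C=CCNc1[nH]nc(N)c1C(=O)Nc1ccc(OCC)cc1`, gives 30800 nM
- compound 3, `CCN/C(SC)=C(/C#N)C(=O)Nc1ccc(OCC)cc1`, gives 41600 nM

Among these three numbers compound 2 holds the second highest. Its nearest neighbour is compound 3, whose number is somewhat higher, but the two lie within the usual scatter of this assay, so nothing can be said about which of them inhibits more strongly. Compound 1 sits further away with a lower number, a gap that exceeds the scatter, so compound 1 inhibits more strongly than compound 2 on this read-out.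

The step examined here leads from compound 2 to compound 4, `CCOc1ccc(NC(=O)c2c(N)n[nH]c2NC)cc1`. The structural change is small: hydrogen in place of vinyl on a saturated chain carbon bound to a nitrogen on an aromatic ring. Put another way, an allylamino group becomes a methylamino group, with everything else in the molecule left untouched. For the measured compounds named here, no pair of measured compounds shows what such a change does here, so the expectation rests on the modest size of the change alone. For compound 4 a step of a 1.1-fold higher number from compound 2 to compound 4 (0.06 log units; within the scatter) is expected, that is, no shift beyond the scatter in either direction. Compound 4 is therefore estimated at 35000 nM, within a range of 14000 nM to 90000 nM.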

Compound 4, half-maximal inhibitory concentration: 31000 nM
For compound 4 the middle estimate is 1.1-fold (0.05 log units) above the measured one; the measured number falls inside the stated range.
By their numbers in this assay, from the lowest: compound 1; then compounds 2, 4 and 3 (each within the scatter of the next).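

In this assay, the first measured single-place comparison among these compounds gives a 1.0-fold higher number from compound 2 to compound 4 (0.00 log units; within the scatter) for putting hydrogen in place of vinyl on a saturated chain carbon bound to a nitrogen on an aromatic ring. Allylamino and methylamino therefore cannot be told apart on this read-out, so for this pair the two carbons and the double bond that leave with the vinyl group make no difference that rises above the scatter. No accompanying measurement bears on why the two compounds read alike.

The compounds shown leave open whether other groups at this place would also read alike, since a longer chain such as hexyl, a benzyl group or a chain ending in a carboxylic acid could still move the number beyond the scatter. For the compounds shown here, with only one step read here, no trend with chain length can be drawn, and it also remains open whether the same swap would read alike on a core such as that of compound 1.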